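Removing a Trifluoromethyl Group: What One Earlier Step Suggests

A few compounds are considered here, and "the series" means these few. Any claim that something is new, unique, unknown or untested is made for them only; others in the source may bear on it.

Compound 1 `Cc1ccc(-c2cn(-c3ccc(CN4CCN(C)CC4)cc3)nn2)cc1Nc1nccc(-c2cccnc2)n1` and compound 2 `Cc1ccc(-c2cn(-c3ccc(CN4CCN(C)CC4)c(C(F)(F)F)c3)nn2)cc1Nc1nccc(-c2cccnc2)n1` share a core and differ in one place. In a functional assay on KG-1a cells (Homo sapiens) for inhibition, read by MTT assay, with a stated time of 72 h (a higher number here means a weaker inhibitor, a lower number a stronger inhibitor), compound 2 gives 1040 nM, and compound 1 gives 6160 nM. The change between them is hydrogen in place of trifluoromethyl on an aromatic carbon and it made a 5.9-fold higher number from compound 2 to compound 1 (0.77 log units; beyond the scatter). Compound 3 `Cc1ccc(-c2nnc(-c3ccc(CN4CCN(CCN=C=S)CC4)c(C(F)(F)F)c3)o2)cc1Nc1nccc(-c2cccnc2)n1` carries a different core; the difference between the two cores is not broken down here. In this assay compound 3 gives 940 nM, a number within the scatter of compound 2. Compound 4 `Cc1ccc(-c2nnc(-c3ccc(CN4CCN(CCN=C=S)CC4)cc3)o2)cc1Nc1nccc(-c2cccnc2)n1` has not yet been measured and differs from compound 3 by hydrogen in place of trifluoromethyl on an aromatic carbon. The surroundings are not described in the same words: in compound 2 the trifluoromethyl sits ortho to a (4-methylpiperazin-1-yl)methyl group (8 heavy atoms), in compound 3 ortho to a large group, so this is the same kind of change rather than the same change. Among the measured compounds shown here, on the basis of a 5.9-fold higher number from compound 2 to compound 1 (0.77 log units; beyond the scatter), the only earlier example of this kind of change, the expected step is a 5.0-fold higher number from compound 3 to compound 4 (0.70 log units; beyond the scatter). Compound 4 is therefore estimated at 4700 nM, likely between 2000 nM and 12000 nM.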

Compound 4, half-maximal inhibitory concentration: 370 nM
Compound 4: middle estimate off by 13-fold (1.10 log units), on the high side, outside the stated range (below it).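

In this assay, putting hydrogen in place of trifluoromethyl on the aromatic carbon gave a 2.5-fold lower number from compound 3 to compound 4 (0.40 log units; beyond the scatter), so the number fell on this core, whereas it had risen on the core of compound 1. Set side by side, the two examples of this change disagree in direction, not only in size: the same change on two cores in this assay, a 5.9-fold higher number (0.77 log units; beyond the scatter) from compound 2 to compound 1 and a 2.5-fold lower number (0.40 log units; beyond the scatter) from compound 3 to compound 4, 15-fold (1.18 log units) apart, beyond the scatter of two such steps. This shows that the result of removing trifluoromethyl on one core cannot safely be carried over to the other in this series, but two pairs cannot show why, as they differ both in the core and in the large group that the trifluoromethyl sits ortho to.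

The compounds shown leave open whether the core or that large group decides the direction of the step, which a compound joining the core of compound 1 to the large group of compound 4 could help to separate. From the compounds shown here alone, it also remains open how a chlorine or a methyl group in the same place would compare with hydrogen and trifluoromethyl on each core.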